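The source may report more compounds than this note shows. Statements on the series, on what has been measured and on what is new or still open speak of the compounds shown alone.

Compound 1 `Cc1ccc(-c2nn(-c3ccccc3)cc2C(=O)NC(=S)Nc2ccc(Cl)cc2)cc1` and compound 2 `O=C(NC(=S)Nc1ccc(Cl)cc1)c1cn(-c2ccccc2)nc1-c1ccc(F)cc1` share one core and differ only in a single group on one of the outer rings. In a functional assay on MCF7 cells (Homo sapiens) for inhibition, read by CCK-8 assay, with a stated time of 48 h (a lower number here means a stronger inhibitor, a higher number a weaker inhibitor), compound 1 gives 6210 nM, and compound 2 gives 5470 nM. The step of a 1.1-fold lower number from compound 1 to compound 2 (0.06 log units; within the scatter) is too small to separate the two: compound 1 and compound 2 sit within the scatter of each other, so neither can be called the stronger inhibitor on these numbers.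

Compound 3 `Cc1ccc(-c2nn(-c3ccccc3)cc2C(=O)NC(=S)Nc2ccc(F)cc2)cc1` is the next member of the series. Compared with compound 1 it carries fluoro in place of chloro on an aromatic carbon. For the measured compounds named here, this is a swap of one halogen for another on the ring attached to the thiourea nitrogen, whereas the only measured step, the one from compound 1 to compound 2, concerns the other outer ring, so it bears on compound 3 only loosely. That step stayed within the scatter, and nothing else in the series points to a change of size. Compound 3 is therefore expected to show a step of about a 1.0-fold lower number from compound 1 to compound 3 (0.01 log units; within the scatter) in this assay, that is, none beyond the scatter. The estimate for compound 3 is 6000 nM, with a range from 3000 nM to 12000 nM.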

Compound 3, half-maximal inhibitory concentration: 6420 nM
Beside the measured number, compound 3's estimate is 1.1-fold (0.03 log units) below it, and the stated range covers the measured number.
By their numbers in this assay, from the lowest: compounds 2, 1 and 3 (each within the scatter of the next).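

Replacing the chloro of the 4-chlorophenyl group with fluoro gives a 1.0-fold higher number from compound 1 to compound 3 (0.01 log units; within the scatter) in this assay. For the compounds shown here, the earlier step concerned only the other outer ring, so this is the first look at the ring on the thiourea nitrogen, and it shows that at this place, on an aromatic carbon para to a large group, one halogen can stand in for the other with no change that can be told from the scatter. No measured evidence on these compounds explains why the two halogens give such similar numbers.

Chloro and fluoro are the only groups on view at this place, and they are both halogens, so it remains open whether the number would move with a group of another kind, such as an amine, a carboxylic acid or a longer chain. As far as these compounds go, it also remains open whether a plain hydrogen at this place would give a similar number, which would show whether the ring needs a group there at all.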